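A New Group on the Carbonyl of Compound 2

The source may hold more compounds than are shown below. What is called first, only, known or untested is meant among the compounds shown, and "the series" means these compounds.

compound 1 `COc1cc(C(=O)c2sc(Nc3ccc(F)cc3)nc2N)cc(OC)c1OC` gives 58 nM
compound 2 `COc1ccc(Nc2nc(N)c(C(=O)c3ccc(Cl)cc3)s2)cc1` gives 59 nM

Going by the values given here, in a functional assay on FM3A cells (Mus musculus) for antiproliferative activity, read by cell counting, with a stated time of 2 days (a higher number here means a weaker inhibitor, a lower number a stronger inhibitor), compound 2 gives 59 nM and compound 1 gives 58 nM as the only other measured value. These two numbers lie within the usual scatter of each other, so neither compound can be ranked above the other.

Compound 3 `COc1ccc(Nc2nc(N)c(C(=O)c3cccc(OC)c3)s2)cc1` has not yet been measured. It differs from compound 2 in one place 3-methoxyphenyl in place of 4-chlorophenyl on a carbonyl carbon and carries 3-methoxyphenyl in place of 4-chlorophenyl on a carbonyl carbon. Among the compounds with values here, no measured pair shows the effect of this swap, so any forecast is uncertain. A modest move toward weaker inhibition in this assay is expected, with an estimated step (a 2.5-fold higher number from compound 2 to compound 3 (0.41 log units; beyond the scatter)) that could still prove small. For compound 3 the estimated value is 150 nM in an expected range from 30 nM to 800 nM in this measurement.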

Compound 3, half-maximal inhibitory concentration: 50 nM
The estimate for compound 3 lay 3.0-fold (0.48 log units) above the measured number; measured number inside the range.
By their numbers in this assay, from the lowest: compounds 3, 1 and 2 (each within the scatter of the next).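

In this assay, 3-methoxyphenyl in place of 4-chlorophenyl on a carbonyl carbon gives a 1.2-fold lower number from compound 2 to compound 3 (0.07 log units; within the scatter), so the two compounds cannot be told apart. Going by these compounds alone, this is the first readable step at this place, and it shows that the number holds even though the chlorine is gone and the entering group brings an oxygen and a hydrogen-bond acceptor that the leaving group lacks. Nothing available explains why these two groups read alike.

Both groups compared here are substituted phenyl rings, so one pair cannot show how much freedom this place really allows. Still open, as far as these compounds go, is what happens with a carboxylic acid or an amine on that ring, or with a longer chain such as ethoxy in place of methoxy.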